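The source may hold more compounds than are shown below. What is called first, only, known or untested is meant among the compounds shown, and "the series" means these compounds.

Values in a functional assay on MCF7 cells (Homo sapiens) for antiproliferative activity, read by sulforhodamine B assay, with a stated time of 48 h; on this read-out lower numbers stand for stronger inhibition and higher numbers for weaker inhibition:
- compound 1 `COc1ccccc1OS(=O)(=O)c1ccc(N2CCN(C)C2=O)cc1`: 26000 nM
- compound 2 `COc1ccc(OS(=O)(=O)c2ccc(N3CCN(C)C3=O)cc2)cc1`: 95000 nM
- compound 3 `CCN1CCN(c2ccc(S(=O)(=O)Oc3ccccc3OC)cc2)C1=O`: > 100000 nM

Compound 3 has no number, only a limit, > 100000 nM. This places it at the limit of > 100000 nM in this assay, at which 1 of the 3 values shown sits.

The next step leads to compound 4 `CCN1CCN(c2ccc(S(=O)(=O)Oc3cccc(Cl)c3)cc2)C1=O`, with 3-chlorophenyl in place of 2-methoxyphenyl on an oxygen.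

One measured step changes the group at this same place: a 3.7-fold higher number from compound 1 to compound 2 (0.56 log units; beyond the scatter), with 4-methoxyphenyl in place of 2-methoxyphenyl. Among the compounds with values here, its size is modest, and no measured compound carries 3-chlorophenyl, so that step gives a size but does not settle the direction for the new group. The other measured step, an at least 3.8-fold higher number from compound 1 to compound 3 (0.58 log units; beyond the scatter), is at least modest and comes from methyl in place of hydrogen on a saturated chain carbon bound to an amide-type nitrogen in a ring. Compound 4 keeps that change.

In this assay, a modest move toward a lower number is therefore expected, though compound 4 may also end up reported only as a limit. The expected step is an at least 1.6-fold lower number from compound 3 to compound 4 (0.22 log units; that floor lies within the scatter). The estimate for compound 4 is 60000 nM, with an expected range of 20000 nM to 150000 nM.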

Compound 4, half-maximal inhibitory concentration: 5400 nM
Beside the measured number, compound 4's estimate is 11-fold (1.05 log units) above it, outside the stated range (below it).
By their numbers in this assay, from the lowest: compound 4; then compound 1; then compound 2. At a limit, above all of these: compound 3.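

In this assay, the place on an oxygen whose other neighbour is the sulfonyl sulfur responds strongly to the group it carries, with 3-chlorophenyl in place of 2-methoxyphenyl giving an at least 18-fold lower number from compound 3 to compound 4 (1.26 log units; beyond the scatter). The earlier step at this place, a 3.7-fold higher number from compound 1 to compound 2 (0.56 log units; beyond the scatter), went toward a higher number, so the group here can move the value in either direction. With the chain change of compound 3 kept, compound 4 still gives 5400 nM. Compound 3 is held only as a limit, which makes the size of the new step a floor: the limit of > 100000 nM in this assay, at which 1 of the 4 values shown sits.

The swap removes the methoxy group and brings in chlorine at a different place on the ring, so the compounds shown cannot separate the effect of the chlorine from the effect of where it sits, and a plain phenyl or a bromophenyl at this place would help to separate them. Also open, on these data alone, is what 3-chlorophenyl does on the core of compound 1, and whether a carboxylic acid or an amine on this ring is accepted.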